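Benzyl Ester in Place of a Free Acid: What to Expect

The source may report more compounds than this note shows. Statements on the series, on what has been measured and on what is new or still open speak of the compounds shown alone.

Of the compounds shown here, three have been measured so far. Compound 1 `O=C(CN(c1nc(Cl)nc2[nH]cnc12)C1CC1)N[C@@H](CO)C(=O)OCc1ccccc1` gives 34.2% in a functional assay on the whole organism (Tail, strain ICR) with Mus musculus as the target, in the tail flick test, with a stated time of 60 min, at a dose of 25 umol/kg by the oral route; a lower number here means a weaker effect, a higher number a stronger effect of the compound at the dose given. Compound 2 `NC(=O)CC[C@H](NC(=O)CN(c1ncnc2c1ncn2C1CCCCO1)C1CC1)C(=O)OCc1ccccc1` gives 39.4% in this assay. Compound 3 `O=C(O)[C@@H]1CCCN1C(=O)CN(c1nc(Cl)nc2[nH]cnc12)C1CC1` gives 34.9% in this assay. Compound 3 stands second highest of the three numbers; its nearest neighbour is compound 1, which lies within the scatter, and its furthest is compound 2, also within the scatter, so the three results cannot be told apart.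

Compound 4 `O=C(OCc1ccccc1)[C@@H]1CCCN1C(=O)CN(c1nc(Cl)nc2[nH]cnc12)C1CC1` has not yet been measured. It differs from compound 3 in one place: benzyl in place of hydrogen on an oxygen next to a carbonyl group, so the carboxy group becomes a benzyloxycarbonyl group. Going by the values given here, no pair of measured compounds differing in a single place exists to show how large such a step usually is. Compound 1 and compound 2 also carry a benzyloxycarbonyl group and give numbers within the scatter of compound 3. For compound 4 the expected step in this assay is therefore a number 2.1 percentage points higher from compound 3 to compound 4 (within the scatter), not beyond the scatter. Compound 4 is expected to give about 37%, within a range from 22% to 54%.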

Compound 4, a percentage reported as activity, at one dose (the size of the read-out at that dose, not a potency): 34.4%
Compound 4: middle estimate off by 2.6 percentage points, on the high side; the range from low to high includes it.
By their numbers in this assay, from the lowest: compounds 1, 4, 3 and 2 (each within the scatter of the next).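

Going by these compounds alone, replacing the hydrogen of the carboxy group with benzyl gives the only single-place step so far. In this assay, this step is small (a number 0.5 percentage points lower from compound 3 to compound 4 (within the scatter)), so at this position, at the dose given, the free acid and its benzyl ester cannot be told apart, even with a six-membered aromatic ring added. Nothing measured here explains this result.

On these data alone, it remains open whether a methyl ester, a longer chain on this oxygen or an amide in place of the ester would move the number beyond the scatter. Also open, as far as these compounds go, is whether a carboxylic acid in place of the benzyloxycarbonyl group of compound 1 would give a similarly small step; a single pair sets no general rule.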